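Swapping the aryl group on the enone of compound 3

This account rests on a few compounds, and the source may have more. Where it says the series, first, only, none or still open, it means among the compounds named here.

Of the compounds shown here, three sharing one core have been tested in an ADME assay on the whole organism for cytotoxicity, with Artemia salina as the target, with a stated time of 24 h; a lower number here means that less compound is needed, a higher number that more compound is needed for the effect. Compound 1 `Cc1ccc(S(=O)(=O)NC(=O)Nc2ccccc2C(=O)/C=C/c2cccc(F)c2)cc1` gives 4.13 ug/mL. Compound 2 `Cc1ccc(S(=O)(=O)NC(=O)Nc2ccccc2C(=O)/C=C/c2cccc(Br)c2)cc1` gives 4.02 ug/mL, and the step of a 1.0-fold lower number from compound 1 to compound 2 (0.01 log units; within the scatter) shows that exchanging one halogen for another leaves the result unchanged. Compound 3 `C=CCOc1ccc(/C=C/C(=O)c2ccccc2NC(=O)NS(=O)(=O)c2ccc(C)cc2)cc1` gives 6.11 ug/mL. Where compound 3 stands among these numbers is told by its two steps: a 1.5-fold higher number from compound 1 to compound 3 (0.17 log units; within the scatter) and a 1.5-fold higher number from compound 2 to compound 3 (0.18 log units; within the scatter), so all three values sit together within the scatter and none can be called different from the others.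

Compound 4 `Cc1ccc(S(=O)(=O)NC(=O)Nc2ccccc2C(=O)/C=C/c2ccncc2)cc1` is the next member and has not yet been measured. Its difference from compound 3 lies at the same place as the earlier changes: pyridin-4-yl in place of 4-(allyloxy)phenyl on a double-bonded chain carbon bound to a double-bonded chain carbon.

The two steps that bear on this position, a 1.5-fold higher number from compound 1 to compound 3 (0.17 log units; within the scatter) and a 1.5-fold higher number from compound 2 to compound 3 (0.18 log units; within the scatter), were both within the scatter, so swapping the aryl group at this position has so far produced no movement in this assay beyond the noise. On that basis the step of a 1.2-fold lower number from compound 3 to compound 4 (0.09 log units; within the scatter) is expected to stay within the scatter as well. Compound 4 is therefore estimated to give 5 ug/mL, with a likely range from 2.5 ug/mL to 10 ug/mL.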

Compound 4, concentration for half-maximal effect: 16.8 ug/mL
For compound 4 the middle estimate is 3.4-fold (0.53 log units) below the measured one; measured number above the stated range.
By their numbers in this assay, from the lowest: compounds 2, 1 and 3 (each within the scatter of the next); then compound 4.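

In this assay this position, on a double-bonded chain carbon bound to a double-bonded chain carbon, does respond to a change of group: pyridin-4-yl gives a 2.7-fold higher number from compound 3 to compound 4 (0.44 log units; beyond the scatter) against 4-(allyloxy)phenyl, a 4.2-fold higher number from compound 2 to compound 4 (0.62 log units; beyond the scatter) against 3-bromophenyl and a 4.1-fold higher number from compound 1 to compound 4 (0.61 log units; beyond the scatter) against 3-fluorophenyl, and all three steps lie beyond the scatter. Among these four compounds, the three with a ring of carbon only stay within the scatter of one another, while the one ring holding a hetero atom stands apart and needs more compound for the effect, something the earlier compounds could not show with their all-carbon rings. Nothing available here explains this shift.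

The compounds shown leave open whether the ring nitrogen itself matters or whether the absence of any substituent on the ring is enough, and a plain phenyl group at this place would separate the two. Also open, going by these compounds, are whether pyridin-3-yl would behave like pyridin-4-yl and how an aryl ring carrying an amine or a carboxylic acid would fare.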